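Methoxycarbonyl for methoxy on the anilino ring

A few compounds are considered here, and "the series" means these few. Any claim that something is new, unique, unknown or untested is made for them only; others in the source may bear on it.

Compound 1 `CCS(=O)(=O)Nc1cc(-c2ccc3ncnc(Nc4cccc(F)c4)c3c2)cnc1OC` gives 3940 nM in a functional assay on HCT-116 cells (Homo sapiens) for cytotoxicity, read by sulforhodamine B assay, with a stated time of 72 h; on this read-out lower numbers stand for stronger inhibition and higher numbers for weaker inhibition. Compound 2 `CCS(=O)(=O)Nc1cc(-c2ccc3ncnc(Nc4ccc(OC(F)(F)F)cc4)c3c2)cnc1OC` gives 16600 nM. Compound 3 `CCS(=O)(=O)Nc1cc(-c2ccc3ncnc(Nc4ccc(OC)c(OC)c4)c3c2)cnc1OC` gives 4360 nM.

Compound 3 stands second highest of the three numbers: its step to compound 1, a 1.1-fold higher number from compound 1 to compound 3 (0.04 log units; within the scatter), falls within the scatter, while a 3.8-fold lower number from compound 2 to compound 3 (0.58 log units; beyond the scatter) goes beyond it. Compound 4 `CCS(=O)(=O)Nc1cc(-c2ccc3ncnc(Nc4ccc(C(=O)OC)c(OC)c4)c3c2)cnc1OC` differs from compound 3 by methoxycarbonyl in place of methoxy on an aromatic carbon. Going by the values given here, no measured step changes the same group, but two steps alter the group para to the large group on the anilino ring: a 4.2-fold higher number from compound 1 to compound 2 (0.62 log units; beyond the scatter) and a 3.8-fold lower number from compound 2 to compound 3 (0.58 log units; beyond the scatter). These show that a change at that carbon can move the number by a modest amount in either direction. Among the compounds with values here, because a 4.2-fold higher number from compound 1 to compound 2 (0.62 log units; beyond the scatter) is the only step where a larger group enters at that carbon and the number rises, compound 4 is expected to give a somewhat higher number, estimated at 7500 nM with a range of 2500 nM to 22000 nM, meaning an expected step of a 1.7-fold higher number from compound 3 to compound 4 (0.24 log units; within the scatter).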

Compound 4, half-maximal inhibitory concentration: 1690 nM
Compound 4: the middle estimate sits 4.4-fold (0.65 log units) above what was measured; the whole stated range lies above it.
By their numbers in this assay, from the lowest: compound 4; then compounds 1 and 3 (each within the scatter of the next); then compound 2.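

In this assay, methoxycarbonyl in place of methoxy on this aromatic carbon gave a 2.6-fold lower number from compound 3 to compound 4 (0.41 log units; beyond the scatter) and thus showed that a larger group at this place can go with a lower number. The 3-methoxy-4-(methoxycarbonyl)phenyl group also compares well with the other two rings on the nitrogen, giving a 9.8-fold lower number from compound 2 to compound 4 (0.99 log units; beyond the scatter) and a 2.3-fold lower number from compound 1 to compound 4 (0.37 log units; beyond the scatter), which makes compound 4 the most potent of the four in this read-out. Nothing given here bears on why the number fell.

The compounds shown leave open whether the whole methoxycarbonyl group is needed, or whether a carboxylic acid or a primary amide on this carbon would give a similar number. They also leave open whether ethoxycarbonyl would do the same, and whether the step holds without the methoxy group ortho to it.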